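This account rests on a few compounds, and the source may have more. Where it says the series, first, only, none or still open, it means among the compounds named here.

Working notes on the triazole-bearing series in a functional assay on HepG2 cells (Homo sapiens) for antiproliferative activity, read by MTT assay, with a stated time of 72 h; a lower number here means a stronger inhibitor, a higher number a weaker inhibitor.

Compound 1 `COc1ccc(-c2cn(C[C@H](O)[C@H]3OC(=O)C(OCc4ccccc4)=C3OCc3ccccc3)nn2)cc1` carries a 4-methoxyphenyl on the triazole and in this assay compound 1 gives 46400 nM. Compound 2 `O=C1O[C@H]([C@@H](O)Cn2cc(CCO)nn2)C(OCc2ccccc2)=C1OCc1ccccc1` has a 2-hydroxyethyl in that position; in this assay compound 2 gives 68100 nM. Among the compounds with values here, the one fully measured step, a 1.5-fold higher number from compound 1 to compound 2 (0.17 log units; within the scatter), shows that exchanging the aromatic group for the short chain leaves the read-out where it was.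

Compound 3 `O=C1O/C(=C\Cn2cc(-c3ccc(Br)cc3)nn2)C(OCc2ccccc2)=C1OCc1ccccc1` has the unsaturated form of the core and a 4-bromophenyl on the triazole. In this assay compound 3 returns only a limit, > 100000 nM, so no number is known for it; it sits at the limit of > 100000 nM in this assay, at which 1 of the 3 values shown sits, and its true value may lie anywhere beyond that.

Compound 4 `COc1ccccc1-c1cn(C/C=C2\OC(=O)C(OCc3ccccc3)=C2OCc2ccccc2)nn1` keeps the unsaturated core of compound 3 and differs only by 2-methoxyphenyl in place of 4-bromophenyl on an aromatic carbon. Within the data shown here, no measured step changes the substituent on the aryl ring, so nothing here bears directly on this exchange; the step from compound 1 to compound 2 is the only comparison available and it was within the scatter. Compound 4 is therefore expected to stay near the limit, with the step that the limit leaves unreadable from compound 3 to compound 4 estimated to be small. The estimate for compound 4 is 120000 nM, in a range from 40000 nM to 400000 nM.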

Compound 4, half-maximal inhibitory concentration: > 100000 nM
Compound 4 was reported as a limit (the forecaster's own chance of this, stated with the estimate: 60%); the middle value does not contradict the limit.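

Compound 4 gives > 100000 nM in this assay, a limit and not a number. Compound 3 also stands at a limit, so no step can be read between compound 3 and compound 4: the limit of > 100000 nM in this assay, at which 2 of the 4 values shown sit.

The compounds shown leave open whether 2-methoxyphenyl in place of 4-bromophenyl changes the read-out at all, and how far either true value lies past the limit.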